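The source may hold more compounds than are shown below. What is called first, only, known or untested is meant among the compounds shown, and "the series" means these compounds.

Measured so far in a functional assay on cells (Cancer cell lines, Homo sapiens) for inhibition; a higher number here means a weaker inhibitor of growth, a lower number a stronger inhibitor of growth:
- compound 1 `N=C(N)N/N=C/c1c(-c2cc(Cl)sc2Cl)nc2n1CCS2` gives 1820 nM
- compound 2 `Cc1cc(-c2nc3sccn3c2/C=N/NC(=N)N)c(C)s1` gives 15500 nM
- compound 3 `Cc1cn2c(/C=N/NC(=N)N)c(-c3cccs3)nc2s1` gives 2570 nM

Compound 1 and compound 3 lie within the scatter of each other, at the low end of these three numbers. Compound 2 has the higher number, and its gap to compound 1 lies beyond the scatter. Compound 4 `N=C(N)N/N=C/c1c(-c2ccsc2)nc2n1CCS2` has not yet been measured. It has thiophen-3-yl in place of 2,5-dichlorothiophen-3-yl on an aromatic carbon and otherwise keeps the core of compound 1.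

Within the data shown here, no pair of measured compounds isolates this change, so any expectation is indirect. Compound 3 has no chlorine and gives 2570 nM in this assay on a different core. Compound 2 also has no chlorine and gives 15500 nM on a different core again. These two values leave the direction open but lean towards a higher number than that of compound 1. A small move in that direction is therefore expected, with the estimated change being a 1.9-fold higher number from compound 1 to compound 4 (0.28 log units; within the scatter) and probably not clearly beyond the scatter. For compound 4 the estimated value is 3500 nM in a range expected to run from 1200 nM to 10000 nM in this measurement.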

Compound 4, concentration for 50% growth inhibition: 22900 nM
The estimate for compound 4 lay 6.5-fold (0.82 log units) below the measured number; measured number outside the range, above it.
By their numbers in this assay, from the lowest: compounds 1 and 3 (each within the scatter of the next); then compounds 2 and 4 (each within the scatter of the next).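

Among these compounds, on the core of compound 1, in this assay, replacing 2,5-dichlorothiophen-3-yl with thiophen-3-yl gives a 13-fold higher number from compound 1 to compound 4 (1.10 log units; beyond the scatter), a large step and the first comparison here that isolates this change. At this aromatic carbon of the five-membered ring with 2 nitrogen, the growth-inhibition number therefore depends strongly on the substituent, even though the thiophene ring itself and the counted hydrogen-bond donors and acceptors stay the same; the two chlorine atoms are the only difference between the two groups. No measurement is available that accounts for this step, so the data record its size but not its cause.

The two chlorine atoms leave together in this step, so the compounds shown do not tell whether one chlorine alone, at either of the two places on the thiophene, would keep the number near that of compound 1. Going by these compounds, it also remains open whether bromine atoms on the thiophene, or a phenyl ring in its place, would do the same on this core, and whether removing the chlorine atoms would have a similar effect on the other cores.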